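A Methyl on the Piperidin-1-yl Group of Compound 1

The source may report more compounds than this note shows. Statements on the series, on what has been measured and on what is new or still open speak of the compounds shown alone.

In a functional assay on A-431 cells (Homo sapiens) for inhibition, with a stated time of 72 h (a higher number here means a weaker inhibitor, a lower number a stronger inhibitor), compound 1 (`COCc1cc(CN2CCCCC2)c(O)c2ncccc12`) gives 22400 nM and compound 2 (`CCOCc1cc(CN2CCCCC2)c(O)c2ncccc12`) gives 23400 nM so the two stand level, within the scatter of each other. Compound 1 therefore has no measured neighbour that separates from it.

Compound 3 (`COCc1cc(CN2CCC(C)CC2)c(O)c2ncccc12`) keeps the core of compound 1 and differs in one place (methyl in place of hydrogen on a saturated ring carbon), with methyl in place of hydrogen on a saturated ring carbon. The same difference reads piperidin-1-yl to 4-methylpiperidin-1-yl.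

Among the measured compounds shown here, only one measured step bears on this change, and only loosely (a 1.0-fold higher number from compound 1 to compound 2 (0.02 log units; within the scatter)). It is also methyl in place of hydrogen, but on a saturated chain carbon bound to an oxygen on a saturated carbon, and it stays within the scatter. For the measured compounds named here, no measured compound carries any change on the ring itself, so the data cannot test this position. No step beyond the scatter is expected in this assay in either direction, although the range must stay wide. Compound 3 is estimated at 19000 nM with an expected range from 9500 nM to 38000 nM in this read-out. That estimate means an expected 1.2-fold lower number from compound 1 to compound 3 (0.07 log units; within the scatter) and nothing beyond the scatter.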

Compound 3, half-maximal inhibitory concentration: 13800 nM
Beside the measured number, compound 3's estimate is 1.4-fold (0.14 log units) above it; low and high end bracket the measured number.
By their numbers in this assay, from the lowest: compounds 3, 1 and 2 (each within the scatter of the next).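

In this assay, the change from piperidin-1-yl to 4-methylpiperidin-1-yl gives a 1.6-fold lower number from compound 1 to compound 3 (0.21 log units; within the scatter), so the saturated ring that carries the ring nitrogen now has a measured substitution of its own, and a methyl on this ring carbon, three ring bonds from that nitrogen, leaves the number level with that of the unsubstituted ring. Among the compounds shown here, the only earlier step, a 1.0-fold higher number from compound 1 to compound 2 (0.02 log units; within the scatter), placed its methyl on the saturated chain instead, and with this result a methyl at either of these two places stays within the scatter of compound 1 in this assay. Nothing measured alongside these numbers offers an explanation for the size of this step.

On these data alone, what stays open is whether a group larger than methyl or of another kind at this ring carbon, such as a hydroxyl, a carboxylic acid or a longer chain, would give a step beyond the scatter. Equally open, as far as these compounds go, is how a methyl on another carbon of the same ring would read, or how a morpholin-4-yl group would read in place of the piperidin-1-yl group on the core of compound 1.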